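This account rests on a few compounds, and the source may have more. Where it says the series, first, only, none or still open, it means among the compounds named here.

Measured in a functional assay on MCF7 cells (Homo sapiens) for inhibition, read by MTT assay, with a stated time of 48 h, tested at 10 uM; on this read-out higher numbers stand for more inhibition of growth at the one concentration tested and lower numbers for less inhibition of growth:
- compound 1 `Cc1cc(=O)c2c(O)cc(OCc3ccccc3)c([C@H]3CCN(C)C[C@H]3O)c2o1`: 1%
- compound 2 `Cc1cc(=O)c2c(O)c(CN3CCC(c4ccccc4)CC3)c(O)c([C@H]3CCN(C)C[C@H]3O)c2o1`: 23%

Compound 2, at 23%, holds the higher of the two numbers, and the gap to compound 1 lies beyond the scatter. Compound 3 `Cc1cc(=O)c2c(O)c(CN3CCCCC3)c(O)c([C@H]3CCN(C)C[C@H]3O)c2o1` is next in this assay. It carries hydrogen in place of phenyl on a saturated ring carbon, three ring bonds from the ring nitrogen: hydrogen in place of phenyl on a saturated ring carbon. For the measured compounds named here, no measured pair isolates this change, so the expectation rests only on compound 2 at 23% and on the structural difference. A modest fall in this assay is expected, and it may not clear the scatter. The expected step is a number 9 percentage points lower from compound 2 to compound 3 (within the scatter). For compound 3 the estimate is 14%, with an expected range of 3% to 30%.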

Compound 3, percent growth inhibition at one concentration: 15%
The estimate for compound 3 lay 1 percentage points below the measured number; low and high end bracket the measured number.
By their numbers in this assay, from the lowest: compound 1; then compounds 3 and 2 (each within the scatter of the next).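

Hydrogen in place of phenyl on a saturated ring carbon, three ring bonds from the ring nitrogen, gives a number 8 percentage points lower from compound 2 to compound 3 (within the scatter) in this assay and so does not separate the two groups. At this position the phenyl can leave without a step that clears the scatter, and compound 3 with hydrogen there gives 15% on this single-concentration read-out, so this pair gives no sign that the phenyl is required. No measurement at hand bears on why this step is as small as it is.

The compounds shown leave open how other groups on this ring carbon, such as hydroxyl, methyl, benzyl or a carboxylic acid, would compare with hydrogen and phenyl. They also leave open whether the same exchange gives a similar step on a different core or at other concentrations.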